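The compounds below may be only part of what the source reports. "The series", "measured", "known", "first", "only" and "open" are said of these compounds alone.

Measured so far in a physicochemical assay for lipophilicity, read by HPLC, measured as chromatographic lipophilicity, at pH 7.4; on this read-out lower numbers stand for lower lipophilicity and higher numbers for higher lipophilicity:
Compound 1 `O=C(c1ccccc1)N1CCC(C(=O)N2N=CCC2c2ccccc2)CC1`: 4.4
Compound 2 `O=C(C1CCN(C(=O)C(F)(F)F)CC1)N1N=CCC1c1ccccc1`: 4.9
Compound 3 `CC(C)(C)C(=O)N1N=CCC1C1CCOCC1`: 4.1

Compound 2, at 4.9, holds the highest number of the three, with compound 1 and compound 3 both lower beyond the scatter. Compound 4 `CN1CCC(C(=O)N2N=CCC2c2ccccc2)CC1` differs from it by one change: methyl in place of (trifluoromethyl)carbonyl on an amine nitrogen in a ring. Within the data shown here, only one measured step bears on this, and only partly: a number 0.50 log units higher from compound 1 to compound 2 (beyond the scatter), a modest one, with trifluoromethyl in place of phenyl on a carbonyl carbon. Among the measured compounds shown here, no measured step removes that carbonyl, so the size is uncertain, but a larger, downward move is expected here. The estimated step is a number 1.90 log units lower from compound 2 to compound 4 (beyond the scatter). Compound 4 is expected at 3, within an estimated range of 2.1 to 3.9.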

Compound 4, distribution coefficient: 1.1
Compound 4: the middle estimate sits 1.90 log units above what was measured, outside the stated range (below it).
By their numbers in this assay, from the lowest: compound 4; then compounds 3 and 1 (each within the scatter of the next); then compound 2.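

Among these compounds, at the amine nitrogen in a ring, the earlier compounds only exchanged one group on the carbonyl for another, whereas methyl removes the carbonyl itself. In this assay this replacement gives two large steps (a number 3.80 log units lower from compound 2 to compound 4 (beyond the scatter); a number 3.30 log units lower from compound 1 to compound 4 (beyond the scatter)), both far bigger than the exchange on the carbonyl carbon (a number 0.50 log units higher from compound 1 to compound 2 (beyond the scatter)). At this position, then, the read-out moves far more when the carbonyl goes than when its substituent changes. Nothing measured here explains the size of this drop.

As far as these compounds go, what stays open is whether the carbonyl's loss or the methyl itself sets the size of the step. The free amine, an ethyl group or an acetyl group on that nitrogen would help separate the two.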